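Swapping cyclopropyl for isopropyl: a half-life estimate

The source may report more compounds than this note shows. Statements on the series, on what has been measured and on what is new or still open speak of the compounds shown alone.

Measured in an in vitro ADME assay on microsomes from liver (Homo sapiens) for metabolic stability, read by LC-MS, using NADPH, tested at 1 uM; on this read-out lower numbers stand for a shorter-lived compound and higher numbers for a longer-lived compound:
- Compound 1 `CC(C)CN1C(=O)CN(Cc2ccc(-c3ccc(F)c(CN4CCCCC4)n3)cc2)C1=O`: 0.217 h
- Compound 2 `CCN1C(=O)CN(Cc2ccc(-c3ccc(F)c(CN4CCCCC4)n3)cc2)C1=O`: 1.45 h
- Compound 3 `O=C1CN(Cc2ccc(-c3cccc(CN4CCCCC4)n3)cc2)C(=O)N1C1CC1`: 2 h

Compound 3 lies within the scatter of compound 2 and clearly beyond the scatter from compound 1, on the longer-lived side. Compound 4 `CC(C)N1C(=O)CN(Cc2ccc(-c3cccc(CN4CCCCC4)n3)cc2)C1=O` has isopropyl in place of cyclopropyl on an amide-type nitrogen in a ring. Among the measured compounds shown here, no measured step makes this exact change. The closest guide is a 6.7-fold higher number from compound 1 to compound 2 (0.82 log units; beyond the scatter), a modest step beyond the scatter in which methyl replaces isopropyl on a saturated chain carbon. That step sits at a different place and on a slightly different core, so it is only a weak guide. Compound 4 is therefore expected to give a somewhat lower number, a 2.0-fold lower number from compound 3 to compound 4 (0.30 log units; within the scatter). Compound 4 is estimated at 1 h, with an expected range from 0.35 h to 2.5 h.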

Compound 4, half-life in the Homo sapiens assay: 1.35 h
Compound 4: the middle estimate sits 1.4-fold (0.13 log units) below what was measured, within the range that was stated.
By their numbers in the Homo sapiens assay, from the lowest: compound 1; then compounds 4, 2 and 3 (each within the scatter of the next).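

At this position, on the amide-type nitrogen in a ring, replacing the three-membered ring of cyclopropyl with the open isopropyl group keeps the reading in the Homo sapiens assay inside the scatter, with a 1.5-fold lower number from compound 3 to compound 4 (0.17 log units; within the scatter) as the step. So, for this pair, the closed ring is not needed for a half-life of this order. In a physicochemical assay for lipophilicity (a lower number here means a more polar compound, a higher number a more lipophilic compound), compound 3 gives 1.6 and compound 4 gives 2.2, so the same swap does register, giving a more lipophilic compound: the measured distribution coefficient of compound 3, 1.6, and of compound 4, 2.2, a number 0.60 log units higher (beyond the scatter).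

Still open, going by these compounds, is how a chain ending in an amine or a hydroxyl group on this nitrogen would behave in either assay.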